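A few compounds are considered here, and "the series" means these few. Any claim that something is new, unique, unknown or untested is made for them only; others in the source may bear on it.

In a physicochemical assay for solubility, using the shake flask method, in phosphate buffer, measured as kinetic solubility, with a stated time of 20 h, at pH 6.5 (a higher number here means a more soluble compound, a lower number a less soluble compound), three compounds share one core and differ only in the group on a nitrogen on an aromatic ring. Compound 1 `COc1ccnc(Nc2cc3[nH]c(-c4cccc(C(F)(F)F)c4)nc3cn2)c1` gives < 5000 nM, which is a limit of the assay and not a number. Compound 2 `COc1ccc(Nc2cc3[nH]c(-c4cccc(C(F)(F)F)c4)nc3cn2)nc1` gives < 5000 nM, which is also a limit. Compound 3 `FC(F)(F)c1cccc(-c2nc3cnc(Nc4ccncn4)cc3[nH]2)c1` gives < 5000 nM, again a limit, so it has no exact place among them. The whole set shows (the limit of < 5000 nM in this assay, at which 3 of the 3 values shown sit).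

Compound 4 `Fc1ccc(Nc2cc3[nH]c(-c4cccc(C(F)(F)F)c4)nc3cn2)nc1` differs from compound 3 by one change, 5-fluoropyridin-2-yl in place of pyrimidin-4-yl on a nitrogen on an aromatic ring: 5-fluoropyridin-2-yl in place of pyrimidin-4-yl. The nearest measured comparison is a step that the two limits leave unreadable from compound 2 to compound 3, and the others are a step that the two limits leave unreadable from compound 1 to compound 2 and a step that the two limits leave unreadable from compound 1 to compound 3. None of these steps has a readable size or direction, so the expectation rests on the shared limit alone. The expected step is a step that the limit leaves unreadable from compound 3 to compound 4, with no firm direction. For compound 4 the estimated value is 2500 nM, within an expected range of 500 nM to 5000 nM, and another limit is the likeliest report.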

Compound 4, solubility: < 5000 nM
Compound 4 gave a limit, no number (the forecaster's own chance of this, stated with the estimate: 85%); the middle value lies beyond the limit too.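

Compound 4 gives < 5000 nM in this assay, which is a limit of the assay and not a number. Going by these compounds alone, no step from compound 1, compound 2 or compound 3 to compound 4 can be read, and the four remain unranked: the limit of < 5000 nM in this assay, at which 4 of the 4 values shown sit. The compounds shown leave open what the exact value of each compound is and whether the group on the nitrogen makes any difference to it.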